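Methoxy for Methyl on the Benzyl Ring of Compound 2

A few compounds are considered here, and "the series" means these few. Any claim that something is new, unique, unknown or untested is made for them only; others in the source may bear on it.

Measured compounds:
compound 1, `CCN(Cc1cccc(Cl)c1)C(=O)C1CCN(S(=O)(=O)c2ccc3cn[nH]c3c2)CC1`: 77%
compound 2, `CCN(Cc1ccccc1C)C(=O)C1CCN(S(=O)(=O)c2ccc3cn[nH]c3c2)CC1`: 103%

In a functional assay on CHO cells for positive allosteric modulation of muscarinic acetylcholine receptor M5 (Homo sapiens), read by calcium flux (on this read-out higher numbers stand for larger maximal responses and lower numbers for smaller maximal responses), compound 2 gives 103% and stands higher than compound 1, which gives 77% in this assay. For the measured compounds named here, the one measured step, a number 26 percentage points higher from compound 1 to compound 2 (beyond the scatter), came from exchanging the whole substituted ring on the saturated chain carbon next to the amide-type nitrogen. Compound 3, `CCN(Cc1ccccc1OC)C(=O)C1CCN(S(=O)(=O)c2ccc3cn[nH]c3c2)CC1`, keeps that ring and alters only its substituent: methoxy in place of methyl on an aromatic carbon. Going by the values given here, no measured pair tests methoxy against methyl, so the single known step bears on the new one only by showing that this part of the molecule can move the maximal response. Among the compounds with values here, with no direct precedent, a step of a number 8 percentage points lower from compound 2 to compound 3 (within the scatter) is expected, within the scatter. Compound 3 is therefore estimated to reach 95% in this assay, with a range from 70% to 115%.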

Compound 3, largest response reached (reported as percent of maximum), in percent of the reference or control that the assay uses: 92%
Estimate against measurement, compound 3: 3 percentage points above, within the range that was stated.
By their numbers in this assay, from the lowest: compound 1; then compound 3; then compound 2.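

In this assay, methoxy in place of methyl on an aromatic carbon ortho to a large group gives a number 11 percentage points lower from compound 2 to compound 3 (beyond the scatter). The earlier step exchanged the whole substituted ring, whereas this one shows that changing only the substituent on that ring can already shift the maximal response. The 2-methoxyphenyl compound still ends above the 3-chlorophenyl compound, with a number 15 percentage points higher from compound 1 to compound 3 (beyond the scatter), but nothing available here accounts for either step.

The compounds shown do not tell what an amine, a nitrile or a longer ether such as ethoxy would do at this place on the ring. They also leave open whether 3-methoxyphenyl would give a response closer to that of 2-methoxyphenyl or of 3-chlorophenyl.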